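The compounds below may be only part of what the source reports. "The series", "measured", "known", "first", "only" and "open" are said of these compounds alone.

Compound 1 `O=C(CSc1nncnc1-c1cccc2ccccc12)Nc1ccccc1Br`: 87000 nM
Compound 2 `COC(=O)c1sccc1NC(=O)CSc1nncnc1-c1ccccc1Cl`: 105000 nM
Compound 3 `Cc1ccc2sc(NC(=O)CSc3nncnc3-c3ccccc3Cl)nc2c1`: 137000 nM

All three were tested in an ADME assay on MT4 cells (Homo sapiens) for cytotoxicity, read by MTT assay; on this read-out higher numbers stand for lower toxicity in this test and lower numbers for higher toxicity in this test. On these numbers compound 2 gives the second of the three, yet its gaps to compound 1 and to compound 3 both fall within the usual scatter, so no order among the three can be claimed. Compound 4 `O=C(CSc1nncnc1-c1ccccc1Cl)Nc1cccnc1Cl` differs from compound 2 in one place: 2-chloropyridin-3-yl in place of 2-(methoxycarbonyl)thiophen-3-yl on an amide-type nitrogen. For the measured compounds named here, no measured pair shows this change, so nothing in the data points in a direction, and a step beyond the scatter is not expected. Compound 4 is estimated at 100000 nM, with a range from 40000 nM to 250000 nM. That estimate means an expected step of a 1.1-fold lower number from compound 2 to compound 4 (0.02 log units; within the scatter), within the scatter.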

Compound 4, half-maximal cytotoxic concentration: 167000 nM
For compound 4 the middle estimate is 1.7-fold (0.22 log units) below the measured one, within the range that was stated.
By their numbers in this assay, from the lowest: compounds 1, 2, 3 and 4 (each within the scatter of the next).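

In this assay, for the compounds shown here, putting 2-chloropyridin-3-yl in place of 2-(methoxycarbonyl)thiophen-3-yl on an amide-type nitrogen gives a 1.6-fold higher number from compound 2 to compound 4 (0.20 log units; within the scatter) and so provides the first one-place comparison here. At this position, exchanging a five-membered aromatic ring for a six-membered one leaves the number within the scatter. Nothing available explains the size of this step.

From the compounds shown here alone, whether an open-chain amine or a carboxylic acid at this position would move the number beyond the scatter remains open. So does whether this same exchange behaves alike on the core of compound 1.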